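A few compounds are considered here, and "the series" means these few. Any claim that something is new, unique, unknown or untested is made for them only; others in the source may bear on it.

Three compounds already have a number in a functional assay on MIA PaCa-2 cells (Homo sapiens) for inhibition, read by MTT assay, with a stated time of 7 days; a higher number here means a weaker inhibitor, a lower number a stronger inhibitor. Compound 1 `CCOC(=O)[C@@H]1CCCN(S(=O)(=O)c2ccc(S(=O)(=O)N(CC)CC)c(F)c2)C1` gives 900 nM. Compound 2 `CCN(CC)S(=O)(=O)c1ccc(S(=O)(=O)N2CCC[C@@H](C(=O)N3CCC(c4nc(C(C)C)no4)CC3)C2)cc1` gives 40 nM. Compound 3 `CC(C)c1noc(N2CCN(C(=O)[C@@H]3CCCN(S(=O)(=O)c4ccc(S(=O)(=O)C5CCC5)cc4)C3)CC2)n1` gives 70 nM. Among these three numbers compound 3 stands second highest: its number and that of compound 2 lie within the usual scatter of each other, so the two cannot be told apart, while compound 1 sits well beyond the scatter on the weaker side.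

Compound 4 `CC(C)c1noc(N2CCN(C(=O)[C@@H]3CCCN(S(=O)(=O)c4ccc(S(=O)(=O)C(C)C)cc4)C3)CC2)n1` has not yet been measured. It differs from compound 3 in a single place: isopropyl in place of cyclobutyl on a sulfonyl sulfur. For the measured compounds named here, no pair of measured compounds shows what this particular swap does in this assay, and the change itself is small, touching only the group on the sulfonyl sulfur. The step from compound 3 to compound 4 is therefore expected to be none beyond the scatter, in either direction. Compound 4 is expected to give about 80 nM, with a range from 35 nM to 180 nM. The expected step is a 1.1-fold higher number from compound 3 to compound 4 (0.06 log units; within the scatter).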

Compound 4, half-maximal inhibitory concentration: 70 nM
Compound 4: middle estimate off by 1.1-fold (0.06 log units), on the high side; low and high end bracket the measured number.
By their numbers in this assay, from the lowest: compounds 2, 3 and 4 (each within the scatter of the next); then compound 1.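

In this assay, isopropyl in place of cyclobutyl on a sulfonyl sulfur gives no change at the digits printed from compound 3 to compound 4 (within the scatter). For the compounds shown here, this is the first direct view of this position: the four-membered ring can be opened to a branched group with one carbon fewer, and the assay cannot tell the two compounds apart. Nothing available here offers a reason for this result.

Going by these compounds alone, this single pair covers only two small carbon groups, so it remains open whether a much larger or very different group on the same sulfonyl sulfur, such as a hexyl chain, a phenyl ring or a chain ending in a carboxylic acid, would leave the number unchanged. Going by these compounds, it also remains open whether this swap would give the same outcome on a different core.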